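The compounds below may be only part of what the source reports. "The series", "measured", "known", "first", "only" and "open" are said of these compounds alone.

In an ADME assay on the whole organism with Oryza sativa as the target, tested at 1 uM (on this read-out higher numbers stand for a weaker effect at the one concentration tested and lower numbers for a stronger effect), compound 3 `CCOC(=O)c1cccc(NC(=O)N[C@@H](C)c2ccccc2)c1` gives 99%, the highest of the three numbers shown, though both neighbours lie within the scatter of it: compound 1 `CCCCCc1ccc(NC(=O)N[C@@H](C)c2ccccc2)cc1` gives 98% and compound 2 `CCOC(=O)c1cccc(NC(=O)N[C@H](C)c2ccccc2)c1` gives 94%. For the measured compounds named here, the only one-place step among the measured compounds is a number 5 percentage points higher from compound 2 to compound 3 (within the scatter), a step that rests on (the fact that compounds 2 and 3 differ only in the configuration as drawn). Compound 4 `C[C@H](NC(=O)Nc1cccc(Cl)c1)c1ccccc1` differs from compound 3 by chloro in place of ethoxycarbonyl on an aromatic carbon. Going by the values given here, no measured step touches a change of this kind, and the one step that was measured stayed within the scatter, so in this assay no step beyond the scatter is expected in either direction. Compound 4 is therefore estimated at 96%, between 86% and 100%, which would mean an expected a number 3 percentage points lower from compound 3 to compound 4 (within the scatter).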

Compound 4, a percentage reported as activity, at one concentration (the size of the read-out at that concentration, not a potency): 99%
Compound 4: middle estimate off by 3 percentage points, on the low side, within the range that was stated.
By their numbers in this assay, from the lowest: compounds 2, 1, 3 and 4 (each within the scatter of the next).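

At this aromatic carbon, meta to a large group, the step for chloro in place of ethoxycarbonyl is no change at the digits printed from compound 3 to compound 4 (within the scatter) in this assay. For the compounds shown here, the earlier compounds held no change at this position, so this is the first reading there, and it shows that a chloro can stand where the ethoxycarbonyl stood without moving the number beyond the scatter. Nothing available bears on the reason for this result. The compounds shown leave open whether an amine, a carboxylic acid or a longer chain at this carbon would give a step beyond the scatter.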